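Swapping cyano for 1-cyanocyclopropyl on compound 3

This account rests on a few compounds, and the source may have more. Where it says the series, first, only, none or still open, it means among the compounds named here.

Measured in a physicochemical assay for lipophilicity, using the shake flask method, at pH 7.4; a higher number here means a more lipophilic compound, a lower number a more polar compound:
- Compound 1 `CC(=O)N1CCN([C@H]2CC[C@H](Nc3nc(Nc4cnn(C)c4)nc4ccc(C#N)cc34)CC2)CC1` gives 2.3
- Compound 2 `COC(=O)N1CCN([C@H]2CC[C@H](Nc3ncnc4ccc(C)nc34)CC2)CC1` gives 2
- Compound 3 `COC(=O)N1CCN([C@H]2CC[C@H](Nc3nc(Nc4cnn(C)c4)nc4ccc(C#N)nc34)CC2)CC1` gives 2.7

Of these three, compound 3 has the highest number in this assay, and compound 1 and compound 2 both lie lower by more than the usual scatter. The next molecule, compound 4 `COC(=O)N1CCN([C@H]2CC[C@H](Nc3nc(Nc4cnn(C)c4)nc4ccc(C5(C#N)CC5)nc34)CC2)CC1`, has 1-cyanocyclopropyl in place of cyano on an aromatic carbon. Going by the values given here, no measured pair shows this swap, so the expectation rests only on the structures, and the entering group holds more heavy atoms and a new ring. A modest rise, slightly beyond the scatter, is expected, estimated as a number 0.40 log units higher from compound 3 to compound 4 (beyond the scatter). Compound 4 is estimated at 3.1, with an expected range of 2.7 to 3.5.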

Compound 4, distribution coefficient: 3.2
For compound 4 the middle estimate is 0.10 log units below the measured one, within the range that was stated.
By their numbers in this assay, from the lowest: compounds 2 and 1 (each within the scatter of the next); then compound 3; then compound 4.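

In this assay, putting 1-cyanocyclopropyl in place of cyano on this aromatic carbon, next to the ring nitrogen, gives a number 0.50 log units higher from compound 3 to compound 4 (beyond the scatter). Going by these compounds alone, this is the first pair here that differs in one place, and both groups hold one triple bond and one hydrogen-bond acceptor, so the entering group differs in its added carbon atoms and three-membered ring. Nothing measured here explains the step. Still open, going by these compounds, is how an amine or a carboxylic acid on this carbon would compare, and whether a larger ring carrying the nitrile would extend the step.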